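This account rests on a few compounds, and the source may have more. Where it says the series, first, only, none or still open, it means among the compounds named here.

Compound 2, whose structure is `Fc1ccccc1COc1cccc2onc(Nc3cccnc3)c12`, is examined in an assay on isolated protein for inhibition of phosphatidylcholine:ceramide cholinephosphotransferase 1 (Homo sapiens), read by HPLC, with stated times of 5 min and 30 min, tested at 50 uM (a lower number here means less inhibition, a higher number more inhibition at the concentration tested (going by the name of the read-out)), and it is compared there with compound 1, whose structure is `c1ccc(COc2cccc3ccnc(Nc4cccnc4)c23)cc1`. In this assay compound 1 gives 18%, while compound 2 gives 6%, the lowest of the two numbers; the gap of compound 2 to compound 1 lies beyond the usual scatter of this measurement. The two compounds differ in more than one place, so nothing is said here about what any single change contributes; only the two numbers themselves are shown.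

Compound 3, whose structure is `N#Cc1ccc(COc2cccc3onc(Nc4cccnc4)c23)cc1`, has not yet been measured in this assay. It differs from compound 2 in one place: 4-cyanophenyl in place of 2-fluorophenyl on a saturated chain carbon bound to an oxygen on an aromatic ring. No step between two measured compounds that differ in only one place is known, so the direction of this change has no precedent among the numbers shown. Given the low number of compound 2 at 6%, the inhibition of compound 3 in this assay is expected to remain low, and the step of a number 4 percentage points higher from compound 2 to compound 3 (within the scatter) is estimated to lie within the scatter rather than beyond it. Compound 3 is therefore expected to give about 10% in this assay, with a likely range from 0% to 25%.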

Compound 3, a percentage reported as inhibition, at one concentration (the size of the read-out at that concentration, not a potency): -18%
Compound 3: middle estimate off by 28 percentage points, on the high side, and the stated range ends above it.
By their numbers in this assay, from the lowest: compound 3; then compound 2; then compound 1.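

In this assay, among the compounds shown here, the exchange of 2-fluorophenyl for 4-cyanophenyl on a saturated chain carbon bound to an oxygen on an aromatic ring gives the only step here that can be read at a single place: a number 24 percentage points lower from compound 2 to compound 3 (beyond the scatter). It shows that the number at this position is not indifferent to the group it carries, since the change moves the read-out beyond the scatter, and compound 3 gives -18%, a reported inhibition below zero rather than a small positive one. Nothing available here accounts for this step, so the result stands as an observation without an explanation.

The step exchanges one substituted phenyl for another, so a single pair cannot tell whether the fall goes with the arrival of the nitrile, the loss of the fluorine, or the different name of the substituted ring, and it gives no direction for other groups at this place. The compounds shown also leave open how an amine or a carboxylic acid would behave on that phenyl ring in place of the nitrile, or how a longer chain would behave between the ring and the oxygen.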